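The source may report more compounds than this note shows. Statements on the series, on what has been measured and on what is new or still open speak of the compounds shown alone.

In a functional assay on A-431 cells (Homo sapiens) for cytotoxicity, read by MTT assay, with a stated time of 24 h (on this read-out lower numbers stand for stronger inhibition and higher numbers for weaker inhibition), compound 3 `COc1ccc(/C=C\C(=O)O)c(OCc2cn(-c3ccc(C#N)cc3)nn2)c1CC=C(C)C` gives 23000 nM, the second highest of the three numbers recorded, with compound 1 `COc1cccc(-n2cc(COc3c(/C=C\C(=O)O)ccc(OC)c3CC=C(C)C)nn2)c1` at 23200 nM and compound 2 `COc1ccc(/C=C\C(=O)O)c(OCc2cn(-c3ccccc3)nn2)c1CC=C(C)C` at 21200 nM; all three lie within the scatter of one another. Compound 4 `COc1ccc(/C=C\C(=O)O)c(OCc2cn(-c3cccc([N+](=O)[O-])c3)nn2)c1CC=C(C)C` differs from compound 3 by 3-nitrophenyl in place of 4-cyanophenyl on an aromatic nitrogen. Among the measured compounds shown here, two measured steps bear on this kind of change at the substituent on the aromatic nitrogen: a 1.0-fold lower number from compound 1 to compound 3 (0.00 log units; within the scatter) and a 1.1-fold higher number from compound 2 to compound 3 (0.04 log units; within the scatter), both within the scatter. Exchanging that substituent among compounds 1, 2 and 3 therefore left the numbers unmoved, and no step beyond the scatter is expected in this assay for compound 4. Compound 4 is accordingly estimated at 22000 nM, between 11000 nM and 44000 nM, which would mean an expected 1.0-fold lower number from compound 3 to compound 4 (0.02 log units; within the scatter).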

Compound 4, half-maximal inhibitory concentration: 18400 nM
Beside the measured number, compound 4's estimate is 1.2-fold (0.08 log units) above it; low and high end bracket the measured number.
By their numbers in this assay, from the lowest: compounds 4, 2, 3 and 1 (each within the scatter of the next).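

Nitro brings a new kind of group to the phenyl ring on the aromatic nitrogen, yet in this assay every step to compound 4 stays within the scatter (a 1.3-fold lower number from compound 3 to compound 4 (0.10 log units; within the scatter); a 1.2-fold lower number from compound 2 to compound 4 (0.06 log units; within the scatter); a 1.3-fold lower number from compound 1 to compound 4 (0.10 log units; within the scatter)). The last of these steps keeps the substituent in the same ring position, going from 3-methoxyphenyl to 3-nitrophenyl, and it too leaves the number within the scatter. Nothing available here explains why these numbers stay together. Going by these compounds, whether an amine or a carboxylic acid on that phenyl ring, or a longer chain in its place, would give a step beyond the scatter remains open.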